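The source may hold more compounds than are shown below. What is called first, only, known or untested is meant among the compounds shown, and "the series" means these compounds.

Measured in an assay on brain for binding affinity to Neuronal acetylcholine receptor; alpha4/beta2 (Rattus norvegicus), read by radioligand binding; on this read-out lower numbers stand for stronger inhibition and higher numbers for weaker inhibition:
compound 1, `Fc1ccc(OC[C@@H]2CCN2)cn1`: 0.057 nM
compound 2, `COc1ccc(OC[C@@H]2CCN2)cn1`: 1.3 nM
compound 3, `Fc1ccc(OC[C@H]2CCN2)cn1`: 0.066 nM

Compound 3 stands second highest of the three numbers in this assay. Its nearest neighbour is compound 1, with a 1.2-fold higher number from compound 1 to compound 3 (0.06 log units; within the scatter); the two compounds differ only in the configuration as drawn (the fact that compounds 1 and 3 differ only in the configuration as drawn), so the shared core with the fluoro substituent gives one number from both drawn forms. The furthest from compound 3 is compound 2, whose number lies well apart.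

The unmeasured compound 4, `Cc1ccc(OC[C@H]2CCN2)cn1`, differs from compound 3 by methyl in place of fluoro on an aromatic carbon. Among the measured compounds shown here, one measured step bears on this position: a 23-fold higher number from compound 1 to compound 2 (1.36 log units; beyond the scatter), a large loss when methoxy enters in place of fluoro. The methyl entering in compound 4 is a different group from methoxy, so the measured step gives only a direction and an upper bound for what to expect. A loss in this assay beyond the scatter is expected, but one that stays short of the methoxy step.

Compound 4 is therefore estimated at 0.3 nM, with a range from 0.08 nM to 1.5 nM. The expected step is a 4.5-fold higher number from compound 3 to compound 4 (0.66 log units; beyond the scatter).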

Compound 4, inhibition constant: 0.053 nM
Compound 4: the middle estimate sits 5.7-fold (0.75 log units) above what was measured; measured number below the stated range.
By their numbers in this assay, from the lowest: compounds 4, 1 and 3 (each within the scatter of the next); then compound 2.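

In this assay, a 1.2-fold lower number from compound 3 to compound 4 (0.10 log units; within the scatter), so at this position next to the ring nitrogen, methyl and fluoro give numbers that cannot be told apart in this drawn form. Among the compounds shown here, the large step seen with methoxy, a 23-fold higher number from compound 1 to compound 2 (1.36 log units; beyond the scatter), therefore does not apply to every replacement of fluoro, although it was read on the other drawn form and the two steps share no compound. Fluoro is thus not needed for a low number in this series, and the compounds at hand offer no measured basis for saying why methyl is tolerated while methoxy is not.

Still open, as far as these compounds go, is where the loss begins between methyl and methoxy, which a longer chain such as ethyl, or an amine at the same position, would help to settle. Also open is whether the two drawn forms stay level once fluoro is replaced by methyl or methoxy, as the only such pair shown carries fluoro: the fact that compounds 1 and 3 differ only in the configuration as drawn.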